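This account rests on a few compounds, and the source may have more. Where it says the series, first, only, none or still open, it means among the compounds named here.

In a functional assay on HCT-116 cells (Homo sapiens) for cytotoxicity, read by sulforhodamine B assay, with a stated time of 48 h (on this read-out lower numbers stand for stronger inhibition and higher numbers for weaker inhibition), compound 1 `CCCCNC(=O)N1Cc2c(NC(=O)c3ccccc3)nn(C(=O)C3CC3)c2C1` gives 3470 nM on the shared core. Compound 2 `CCCCNC(=O)N1Cc2c(NC(=O)c3ccc(C)cc3)nn(C(=O)C3CC3)c2C1` gives 17600 nM in the same test, and compound 3 `CCCCNC(=O)N1Cc2c(NC(=O)c3ccc(F)cc3)nn(C(=O)C3CC3)c2C1` stands at 23300 nM in that test. Methyl in place of hydrogen on an aromatic carbon brought a 5.1-fold higher number from compound 1 to compound 2 (0.71 log units; beyond the scatter) and fluoro in its place brought a 6.7-fold higher number from compound 1 to compound 3 (0.83 log units; beyond the scatter) as a comparable modest step. Compound 3 therefore sits level with compound 2 and well above compound 1. The gap between those two level compounds is a 1.3-fold higher number from compound 2 to compound 3 (0.12 log units; within the scatter) and no more.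

Compound 4 `CCCCNC(=O)N1Cc2c(NC(=O)c3ccc(OC)cc3)nn(C(=O)C3CC3)c2C1` has not yet been measured. It carries methoxy in place of fluoro on an aromatic carbon in the same place, para to a large group. Among the measured compounds shown here, the closest precedent is a 1.3-fold higher number from compound 2 to compound 3 (0.12 log units; within the scatter) for one group replacing another there, so no change beyond the scatter is expected. The expected step is a 1.3-fold lower number from compound 3 to compound 4 (0.11 log units; within the scatter) in this assay on this reasoning. The estimated value for compound 4 is 18000 nM with an expected range of 6000 nM to 45000 nM for this measurement.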

Compound 4, half-maximal inhibitory concentration: 65500 nM
Compound 4: the middle estimate sits 3.6-fold (0.56 log units) below what was measured, and the stated range ends below it.
By their numbers in this assay, from the lowest: compound 1; then compounds 2 and 3 (each within the scatter of the next); then compound 4.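

Methyl and fluoro could not be told apart at this place on the aromatic ring, but methoxy can be told from both in this assay: the change gives a 2.8-fold higher number from compound 3 to compound 4 (0.45 log units; beyond the scatter) and also a 3.7-fold higher number from compound 2 to compound 4 (0.57 log units; beyond the scatter) in the same direction. Among the compounds shown here, the groups at this place therefore do not all give the same number, and the change from hydrogen to methoxy, with a 19-fold higher number from compound 1 to compound 4 (1.28 log units; beyond the scatter) as its result, is the first large step seen there, leaving compound 1 with the lowest number of the four. Nothing available here accounts for why methoxy differs from methyl and fluoro.

Going by these compounds, whether an amine or a hydroxyl group at this place would bring the number back towards that of compound 1 remains open. So does whether a longer ether such as ethoxy would raise it further.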